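Compound 3 to compound 4: a side-chain exchange

The source may report more compounds than this note shows. Statements on the series, on what has been measured and on what is new or still open speak of the compounds shown alone.

Going by the values given here, in an ADME assay for permeability, using PAMPA, with a stated time of 4 h, at pH 7.4 (on this read-out higher numbers stand for higher permeability and lower numbers for lower permeability), compound 3 `c1ccc2c(c1)CN[C@@H](CN(CCN1CCNCC1)[C@H]1CCCc3cccnc31)C2` gives 10 nm/s as the lowest of the three numbers so far. Compound 2 `CCN1CCN(CCCN(C[C@H]2Cc3ccccc3CN2)[C@H]2CCCc3cccnc32)CC1` gives 317 nm/s and compound 1 `CN1CCN(CCCN(C[C@H]2Cc3ccccc3CN2C)[C@H]2CCCc3cccnc32)CC1` gives 513 nm/s on the same scale, and both lie beyond the scatter from compound 3.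

Compound 4 `CN1CCN(CCCN(C[C@H]2Cc3ccccc3CN2)[C@H]2CCCc3cccnc32)CC1` differs from compound 3 by (4-methylpiperazin-1-yl)methyl in place of piperazin-1-yl on a saturated chain carbon, two bonds along the chain from an amine nitrogen so that (4-methylpiperazin-1-yl)methyl stands in place of piperazin-1-yl on a saturated chain carbon, two bonds along the chain from an amine nitrogen. Among the compounds with values here, only one measured step bears on this change. The large step of a 32-fold lower number from compound 2 to compound 3 (1.50 log units; beyond the scatter) puts piperazin-1-yl in place of (4-ethylpiperazin-1-yl)methyl at the same place, which runs nearly the reverse way with ethyl instead of methyl. A large step to a higher number is therefore expected in this assay although the evidence is that single step. The expected change is a 26-fold higher number from compound 3 to compound 4 (1.41 log units; beyond the scatter) and would lie beyond the scatter. Compound 4 is estimated at 260 nm/s within an expected range from 110 nm/s to 520 nm/s in this measurement.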

Compound 4, apparent permeability: 360 nm/s
Estimate against measurement, compound 4: 1.4-fold (0.14 log units) below; the measured number falls inside the stated range.
By their numbers in this assay, from the lowest: compound 3; then compounds 2, 4 and 1 (each within the scatter of the next).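

In this assay, the step from piperazin-1-yl to (4-methylpiperazin-1-yl)methyl at this place is now measured directly, as a 36-fold higher number from compound 3 to compound 4 (1.56 log units; beyond the scatter), so the large gap seen with the ethyl-bearing compound 2 also appears with a methyl group on the piperazine. The terminal group makes no difference beyond the scatter among these compounds, as ethyl against methyl gives a 1.1-fold higher number from compound 2 to compound 4 (0.06 log units; within the scatter). Methyl against hydrogen on the ring amine nitrogen of the core also stays within the scatter, giving a 1.4-fold lower number from compound 1 to compound 4 (0.15 log units; within the scatter).

The exchange adds to the chain and removes a hydrogen-bond donor in a single step, so these compounds cannot separate the two changes; a (piperazin-1-yl)methyl group at this place would bear on that question. Nothing in the available data accounts for the size of the step.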